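The source may report more compounds than this note shows. Statements on the series, on what has been measured and on what is new or still open speak of the compounds shown alone.

Measured compounds:
Compound 1 `CC(=O)Nc1ccc(CNC2CCN(CCCc3c[nH]c4ccc(-n5cnnc5)cc34)CC2)cc1`: 5 nM
Compound 2 `OC[C@H](NC1CCN(CCCc2c[nH]c3ccc(Cn4cncn4)cc23)CC1)c1ccccc1`: 32 nM
Compound 3 `COC[C@H](NC1CCN(CCCc2c[nH]c3ccc(Cn4cncn4)cc23)CC1)c1ccc(F)cc1`: 8.9 nM

In an assay on CHO cells for agonist activity at 5-hydroxytryptamine receptor 1D (Homo sapiens), read by GTPgammaS binding (on this read-out lower numbers stand for an effect already at smaller amounts and higher numbers for an effect only at larger amounts of compound), compound 1 gives the lowest of the three numbers; compound 3 lies within the scatter of it, while compound 2 lies beyond it. Compound 4 `CC(CO)(NC1CCN(CCCc2c[nH]c3ccc(-n4cnnc4)cc23)CC1)c1ccccc1` is not yet measured. It differs from compound 1 by 1-(hydroxymethyl)-1-phenylethyl in place of 4-acetamidobenzyl on an amine nitrogen. Among the measured compounds shown here, the one step seen so far on the same amine nitrogen, a 3.6-fold lower number from compound 2 to compound 3 (0.56 log units; beyond the scatter), exchanged different groups, so it bears only loosely on this change; it shows that variation at this position moves the number by a modest amount. A modest step, if any, is therefore expected for compound 4 in this assay, more likely toward a higher number given the already low value of compound 1. The estimate for compound 4 is 12 nM, between 3.5 nM and 40 nM, a step of a 2.4-fold higher number from compound 1 to compound 4 (0.38 log units; beyond the scatter).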

Compound 4, half-maximal effective concentration: 3.4 nM
Beside the measured number, compound 4's estimate is 3.5-fold (0.55 log units) above it; measured number outside the range, below it.
By their numbers in this assay, from the lowest: compounds 4, 1 and 3 (each within the scatter of the next, the first and the last beyond it); then compound 2.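

In this assay the exchange on the amine nitrogen gives a 1.5-fold lower number from compound 1 to compound 4 (0.17 log units; within the scatter) and so leaves the number where it was. At this position, then, a group without the nitrogen of 4-acetamidobenzyl, and with its hydroxymethyl and methyl on the carbon bound to the amine nitrogen, keeps the low number on the core of compound 1. The data offer no explanation for this match.

What the hydroxymethyl itself contributes stays open, since no compound shown carries an aminomethyl, a carboxylic acid or a plain methyl in its place on this core.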